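A Methyl on the Ring and Antagonist Dose in Mice

A few compounds are considered here, and "the series" means these few. Any claim that something is new, unique, unknown or untested is made for them only; others in the source may bear on it.

Compound 1 `CC(=O)N(C)C(C)C#CCn1ccnc1` was tested in a functional assay on the whole organism for antagonist activity, with Mus musculus as the target; a higher number here means that more compound is needed for the effect, a lower number that less compound is needed. In this assay compound 1 gives only a limit, > 100 mg/kg. Compound 2 `CC(=O)N(C)C(C)C#CCn1cncc1C` carries methyl in place of hydrogen on an aromatic carbon and in this assay gives 3.7 mg/kg, so that an at least 27-fold lower number from compound 1 to compound 2 (1.43 log units; beyond the scatter). Compound 3 `O=C1OCCN1CC#CCn1ccnc1` has a different core from compound 1; the difference between the two cores is not broken down here. In this assay compound 3 also gives only a limit, > 100 mg/kg, which is the limit of > 100 mg/kg in this assay, at which 2 of the 3 values shown sit. Compound 4 `Cc1cncn1CC#CCN1CCOC1=O` is compound 3 with the same change, (methyl in place of hydrogen on an aromatic carbon). Because an at least 27-fold lower number from compound 1 to compound 2 (1.43 log units; beyond the scatter), a step of similar size is expected from compound 3 to compound 4, namely an at least 10-fold lower number from compound 3 to compound 4 (1.00 log units; beyond the scatter). Compound 3 may, however, sit anywhere beyond its limit. Compound 4 is therefore estimated at 10 mg/kg, expected between 2 mg/kg and 100 mg/kg.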

Compound 4, dose for half-maximal effect: 80 mg/kg
For compound 4 the middle estimate is 8.0-fold (0.90 log units) below the measured one; measured number inside the range.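

Carried to the core of compound 3, methyl in place of hydrogen on an aromatic carbon gives an at least 1.2-fold lower number from compound 3 to compound 4 (0.09 log units; that floor lies within the scatter). This shows that the change does not give a higher number on the second core, but it does not show a step beyond the scatter there, nor that the step keeps its size from one core to the other. Set beside the earlier step, the result stays undecided: the same change on two cores in this assay, an at least 27-fold lower number (1.43 log units; beyond the scatter) from compound 1 to compound 2 and an at least 1.2-fold lower number (0.09 log units; that floor lies within the scatter) from compound 3 to compound 4; the limit leaves it open whether they differ

The compounds shown leave open where compound 1 and compound 3 really lie beyond their limits: the limit of > 100 mg/kg in this assay, at which 2 of the 4 values shown sit. Also open is whether an ethyl or a chlorine on that aromatic carbon would follow the same course on either core.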